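This account rests on a few compounds, and the source may have more. Where it says the series, first, only, none or still open, it means among the compounds named here.

Measured so far in a physicochemical assay for lipophilicity, at pH 7.4; on this read-out lower numbers stand for lower lipophilicity and higher numbers for higher lipophilicity:
- compound 1 `CCCCCCC/C=C/c1c(C)[nH]c2ccccc2c1=O`: 4.26
- compound 2 `Cc1[nH]c2ccccc2c(=O)c1/C=C/C(=O)OC(C)(C)C`: 2.34
- compound 3 `Cc1[nH]c2ccccc2c(=O)c1/C=C/c1ccccc1`: 4.4

Compound 3 shares the top of this range with compound 1, as the step of a number 0.14 log units higher from compound 1 to compound 3 (within the scatter) shows. It stands well clear of the remaining compound: a number 2.06 log units higher from compound 2 to compound 3 (beyond the scatter).

Compound 4 `Cc1[nH]c2ccccc2c(=O)c1/C=C/c1cccc([N+](=O)[O-])c1` differs by one change: nitro in place of hydrogen on an aromatic carbon, meta to a large group. Going by the values given here, no measured step alters that ring. Both steps to compound 3, a number 0.14 log units higher from compound 1 to compound 3 (within the scatter) and a number 2.06 log units higher from compound 2 to compound 3 (beyond the scatter), replace a whole chain end, so they guide only loosely. Adding one group is a smaller edit, so a slight drop within the scatter is expected in this assay. The expected step is a number 0.20 log units lower from compound 3 to compound 4 (within the scatter). For compound 4 the estimated value is 4.2, with an expected range from 3.7 to 4.7.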

Compound 4, distribution coefficient: 2.95
Compound 4: the middle estimate sits 1.25 log units above what was measured; measured number outside the range, below it.
By their numbers in this assay, from the lowest: compound 2; then compound 4; then compounds 1 and 3 (each within the scatter of the next).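

In this assay, nitro in place of hydrogen on an aromatic carbon, meta to a large group, gives a number 1.45 log units lower from compound 3 to compound 4 (beyond the scatter). Going by these compounds alone, this ring had not been changed in the earlier compounds, and the result shows that an edit of just 3 heavy atoms here can produce a large step, a size earlier seen only when a whole chain end was replaced. Nothing measured here accounts for the size of this step.

As far as these compounds go, whether an amine or a carboxylic acid at this carbon would shift the number as far remains open. A single substituted compound also cannot separate the effect of nitro itself from that of its place on the ring.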